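Replacing chloro with methoxy in compound 3

The source may report more compounds than this note shows. Statements on the series, on what has been measured and on what is new or still open speak of the compounds shown alone.

- compound 1 `O=C1/C(=C/c2ccc(Cl)cc2)CCC/C1=C\c1cccc([N+](=O)[O-])c1` gives 5.58
- compound 2 `COc1ccc(/C=C2\CCC/C(=C\c3cccc([N+](=O)[O-])c3)C2=O)cc1` gives 4.96
- compound 3 `O=C1/C(=C/c2ccc(Cl)cc2)CCC/C1=C\c1ccc([N+](=O)[O-])cc1` gives 5.6

Measured by a physicochemical assay for lipophilicity (a higher number here means a more lipophilic compound, a lower number a more polar compound), compound 3 at 5.6 stands within the scatter of compound 1 at 5.58 and the two cannot be ranked. Compound 2 at 4.96 lies lower than both of them, beyond the scatter.

Compound 4 `COc1ccc(/C=C2\CCC/C(=C\c3ccc([N+](=O)[O-])cc3)C2=O)cc1` has not yet been measured. It differs from compound 3 by methoxy in place of chloro on an aromatic carbon, para to a large group, a change that also reads 4-chlorophenyl to 4-methoxyphenyl (methoxy in place of chloro on an aromatic carbon).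

Going by the values given here, one measured step bears on this change. The same replacement gives a number 0.62 log units lower from compound 1 to compound 2 (beyond the scatter) as a modest move beyond the scatter, and that pair differs from the pair at hand only in where the nitro group stands. A step of about that size, downward and beyond the scatter, is therefore expected in this assay here, although the expectation rests on this single precedent. The expected change, estimated from that one step, is a number 0.62 log units lower from compound 3 to compound 4 (beyond the scatter) in the same direction. The estimate for compound 4 is 4.98 with an expected range from 4.7 to 5.3 as its bounds.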

Compound 4, partition coefficient: 4.98
Estimate against measurement, compound 4: no gap at the digits printed, and the stated range covers the measured number.
By their numbers in this assay, from the lowest: compounds 2 and 4 (each within the scatter of the next); then compounds 1 and 3 (each within the scatter of the next).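

The replacement of chloro with methoxy on an aromatic carbon now has a second reading in this assay: a number 0.62 log units lower from compound 3 to compound 4 (beyond the scatter), the same size as a number 0.62 log units lower from compound 1 to compound 2 (beyond the scatter), and both steps lie beyond the scatter. The earlier compounds shown here showed this step with the nitro group in only one place, whereas the two pairs now show it with the nitro group in either of two places on the second aromatic ring. Moving the nitro group leaves compounds 1 and 3 within the scatter of each other and compounds 2 and 4 within the scatter of each other, so among these four compounds the change from 4-chlorophenyl to 4-methoxyphenyl is the only one that separates the numbers beyond the scatter.

The compounds shown leave open how other groups at this place, such as a hydroxyl, an amine or a carboxylic acid, would compare with chloro and methoxy, and whether the step keeps its size when the nitro group gives way to a nitrile or an amine. Nothing among the data shown explains the size of this step or why it repeats across the two pairs.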